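A sulfur-bearing group in place of a nitrogen-rich one

The source may report more compounds than this note shows. Statements on the series, on what has been measured and on what is new or still open speak of the compounds shown alone.

Compound 1 `CN(C)/C(=N/CCCCn1nc(-c2ccccc2)ccc1=O)NC#N` is the anchor of this small set. Going by the values given here, in a functional assay on the whole organism (stomach) with Rattus norvegicus as the target (on this read-out higher numbers stand for an effect only at larger amounts of compound and lower numbers for an effect already at smaller amounts), compound 1 gives 30.3 mg/kg, and this is the only actual number known so far. For compound 2 `C/N=C(\S)NCCCn1nc(-c2ccccc2)ccc1=O` this assay records > 100 mg/kg, which is a limit of the measurement and not a number: the limit of > 100 mg/kg in this assay, at which 1 of the 2 values shown sits.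

Compound 3 `CC(C)C/N=C(\S)NCCCCn1nc(-c2ccccc2)ccc1=O` has not been measured. It differs from compound 1 by a group of 8 heavy atoms (5 carbon, 2 nitrogen, 1 sulfur; no ring) in place of a group of 8 heavy atoms (4 carbon, 4 nitrogen; no ring), on a saturated chain carbon, four bonds along the chain from an aromatic nitrogen

Because compound 2, which also carries a sulfur-bearing group, gives > 100 mg/kg in this assay, compound 3 is expected to need a larger dose than compound 1. The expected step from compound 1 to compound 3 is a 2.1-fold higher number from compound 1 to compound 3 (0.33 log units; beyond the scatter), toward weaker effect and beyond the usual scatter. For compound 3 the estimate in this assay is 65 mg/kg, within a range from 25 mg/kg to 150 mg/kg, with a real chance that only a limit is reported.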

Compound 3, dose for half-maximal effect: > 100 mg/kg
Compound 3 was reported as a limit (the forecaster's own chance of this, stated with the estimate: 35%); at least 1.5-fold (0.18 log units) between middle value and limit.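

Swapping the group of 8 heavy atoms (4 carbon, 4 nitrogen; no ring) for the group of 8 heavy atoms (5 carbon, 2 nitrogen, 1 sulfur; no ring), on a saturated chain carbon, four bonds along the chain from an aromatic nitrogen, gives in this assay an at least 3.3-fold higher number from compound 1 to compound 3 (0.51 log units; beyond the scatter), the first step in this set that can be read at a single place. The value of compound 3 is a limit and not a number, so this step gives only the smallest size the change can have. The two sulfur-bearing compounds cannot be ranked against each other: the limit of > 100 mg/kg in this assay, at which 2 of the 3 values shown sit.

On these data alone, whether a carboxylic acid or a simple amine at this place would keep the dose close to that of compound 1 stays open. The values also do not separate the sulfur atom from the rest of the entering group, as the two change together.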